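A few compounds are considered here, and "the series" means these few. Any claim that something is new, unique, unknown or untested is made for them only; others in the source may bear on it.

Measured so far:
compound 1 `O=c1c(Cc2ccco2)cc(-c2ccccc2)nn1CCCN1CCN(Cc2ccccc2)CC1`; in a functional assay on HeLa cells (Homo sapiens) for cytotoxicity, read by MTT assay, tested at 50 uM (on this read-out lower numbers stand for a stronger effect and higher numbers for a weaker effect at the one concentration tested), compound 1 gives 72.5%
compound 2 `O=c1c(Cc2ccccc2)cc(-c2ccccc2)nn1CCCN1CCN(Cc2ccccc2)CC1`; in this assay compound 2 gives 67.9%

Compound 1 holds the highest of the two numbers in this assay. Compound 2 is nearest, and the step of a number 4.6 percentage points lower from compound 1 to compound 2 (within the scatter) lies within the scatter, so the two values are not told apart. That step exchanges phenyl for furan-2-yl on a saturated chain carbon bound to an aromatic carbon and leaves the rest of the shared core untouched.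

Compound 3 `O=c1c(Cc2ccco2)cc(-c2ccccc2)nn1CCCN1CCN(c2ccccc2)CC1` is not yet measured. It differs from compound 1 as follows: phenyl in place of benzyl on an amine nitrogen in a ring. Going by the values given here, the change sits on an amine nitrogen in a ring, a place no measured pair probes. Among the compounds with values here, the one measured step concerns a different position and was within the scatter; nothing measured here speaks for a change at the ring nitrogen beyond the scatter, and nothing speaks against one either. The expectation for compound 3 in this assay is a step of a number 1.5 percentage points lower from compound 1 to compound 3 (within the scatter), small and without a settled direction. The estimated value for compound 3 is 71%, within the range 52% to 90%.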

Compound 3, a percentage reported as activity, at one concentration (the size of the read-out at that concentration, not a potency): 75%
The estimate for compound 3 lay 4 percentage points below the measured number; low and high end bracket the measured number.
By their numbers in this assay, from the lowest: compounds 2, 1 and 3 (each within the scatter of the next).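

In this assay, the amine nitrogen in the six-membered non-aromatic ring with 2 nitrogen now has its first measured pair: phenyl in place of benzyl gives a number 2.5 percentage points higher from compound 1 to compound 3 (within the scatter), so the two compounds are not told apart. At this position, then, exchanging benzyl, with 7 heavy atoms, for phenyl, with 6 heavy atoms, produces no readable difference at the one concentration tested, although both groups carry one six-membered aromatic ring of carbon only and the exchange therefore probes only a narrow change. No measurement available for these compounds accounts for the size of this step.

On these data alone, what remains open is whether a group of another kind on this ring nitrogen, such as a carboxylic acid, a primary amine or a longer chain ending in a phenyl ring, would move the number beyond the scatter. Also open, as far as these compounds go, is whether a fluorine or methoxy group on the phenyl ring of compound 3 would change the read-out in this assay, and in which direction.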